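The source may hold more compounds than are shown below. What is called first, only, known or untested is meant among the compounds shown, and "the series" means these compounds.

Series notes. Three compounds of the set carry a number or a limit in a functional assay on PC-3 cells (Homo sapiens) for cytotoxicity, read by MTT assay, with a stated time of 72 h; on this read-out higher numbers stand for weaker inhibition and lower numbers for stronger inhibition. Compound 1 `C=C(C)CCOc1ccc(C(C)=O)c(O)c1` reaches only the limit > 100000 nM. Compound 3 `CC(C)=CCOc1ccc(C(=O)/C=C/c2ccc(O)cc2)c(O)c1` likewise reaches only the limit > 100000 nM. Among the compounds with values here, compound 2 `COc1cc(/C=C/C=O)cc(OC)c1OC/C=C(\C)CCC=C(C)C` is the one member with a number, giving 39000 nM in this assay; it stands alone against (the limit of > 100000 nM in this assay, at which 2 of the 3 values shown sit), so no measured step within the set can be drawn. The next compound, compound 4 `COc1cc(/C=C/C=O)cc(OC)c1OCC=C(C)C`, differs from compound 2 in one place: hydrogen in place of 3-methylbut-2-en-1-yl on a saturated chain carbon bound to a double-bonded chain carbon. Within the data shown here, no step of this kind has been measured here, so the direction rests on nothing firmer than the one number for compound 2; a small loss beyond the scatter is expected, a 1.4-fold higher number from compound 2 to compound 4 (0.15 log units; within the scatter). Compound 4 is accordingly estimated at 55000 nM in this assay, within 20000 nM to 120000 nM.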

Compound 4, half-maximal inhibitory concentration: 28000 nM
Compound 4: the middle estimate sits 2.0-fold (0.29 log units) above what was measured; low and high end bracket the measured number.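

In this assay, the series now has its first measured step: a 1.4-fold lower number from compound 2 to compound 4 (0.14 log units; within the scatter). At this saturated chain carbon bound to a double-bonded chain carbon, replacing 3-methylbut-2-en-1-yl with hydrogen therefore shifts the read-out by no more than the scatter, in this single pair. Compounds 1 and 3 offer no comparable step, and both give only a limit: the limit of > 100000 nM in this assay, at which 2 of the 4 values shown sit.

On these data alone, what a chain ending in an amine or a carboxylic acid would give at this place remains open. So does whether a longer chain would stay within the scatter.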